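A few compounds are considered here, and "the series" means these few. Any claim that something is new, unique, unknown or untested is made for them only; others in the source may bear on it.

Series notes. Compound 3 `CCN1CCN(c2cc(C)c3cc(NC(=O)c4cccnc4)ccc3n2)CC1` stands second highest of the three numbers in a functional assay on MCF7 cells (Homo sapiens) for antiproliferative activity, read by MTT assay, with a stated time of 72 h; a lower number here means a stronger inhibitor, a higher number a weaker inhibitor: compound 3 gives 26600 nM, compound 1 `CCN1CCN(c2cc(C)c3cc(NC(=O)c4ccccc4F)ccc3n2)CC1` gives 32600 nM, and compound 2 `CCN1CCN(c2cc(C)c3cc(NC(=O)c4ccc(OC)cc4)ccc3n2)CC1` gives 7690 nM. The step of a 1.2-fold lower number from compound 1 to compound 3 (0.09 log units; within the scatter) is within the scatter, whereas a 3.5-fold higher number from compound 2 to compound 3 (0.54 log units; beyond the scatter) lies beyond it. Compound 4 `CCN1CCN(c2cc(C)c3cc(NC(=O)c4cc5ccccc5[nH]4)ccc3n2)CC1` is not yet measured; it differs from compound 3 by 1H-indol-2-yl in place of pyridin-3-yl on a carbonyl carbon. The steps at this carbonyl carbon, a 4.2-fold lower number from compound 1 to compound 2 (0.63 log units; beyond the scatter) and a 3.5-fold higher number from compound 2 to compound 3 (0.54 log units; beyond the scatter), moved the number by modest amounts at most. For the measured compounds named here, no measured step covers a two-ring group here, so compound 4 is expected to show a step of a 1.8-fold lower number from compound 3 to compound 4 (0.25 log units; within the scatter), toward a lower number but not firmly beyond the scatter. The estimate for compound 4 is 15000 nM, ranging from 4000 nM to 50000 nM.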

Compound 4, half-maximal inhibitory concentration: 2950 nM
Beside the measured number, compound 4's estimate is 5.1-fold (0.71 log units) above it; the measured number lies below the stated range.
By their numbers in this assay, from the lowest: compound 4; then compound 2; then compounds 3 and 1 (each within the scatter of the next).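

Against every single-ring group so far, 1H-indol-2-yl on this carbonyl carbon gives a lower number in this assay, with steps of a 9.0-fold lower number from compound 3 to compound 4 (0.96 log units; beyond the scatter) and an 11-fold lower number from compound 1 to compound 4 (1.04 log units; beyond the scatter), and even a 2.6-fold lower number from compound 2 to compound 4 (0.42 log units; beyond the scatter) lies beyond the scatter. A two-ring group carrying a hydrogen-bond donor is thus accepted at this position and reaches lower numbers than the earlier groups did. Nothing at hand explains these steps.

Open, as far as these compounds go, is whether the donor or the second ring matters, which naphthalen-2-yl or benzofuran-2-yl on this carbon would separate.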